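The source may hold more compounds than are shown below. What is called first, only, known or untested is meant among the compounds shown, and "the series" means these compounds.

In an ADME assay on HEK293 cells (Homo sapiens) for inhibition, read by MTT assay, with a stated time of 48 h (on this read-out lower numbers stand for stronger inhibition and higher numbers for weaker inhibition), compound 1 `C(=C/c1nc2ccccn2c1Sc1ccccc1)\c1ccccc1` gives > 100000 nM, which is a limit and not a number. Compound 2 `CSc1ccc(-c2nc3ccccn3c2Sc2ccccc2)cc1` gives > 100000 nM, also a limit. Compound 3 `c1ccc(Sc2c(-c3cccs3)nc3ccccn23)cc1` gives > 100000 nM, again a limit, so it shares the limit of > 100000 nM in this assay, at which 3 of the 3 values shown sit, and has no number of its own.

Compound 4 `Clc1ccc(Sc2c(-c3cccs3)nc3ccccn23)cc1` differs from compound 3 by chloro in place of hydrogen on an aromatic carbon, which turns phenyl to 4-chlorophenyl. The steps that reach compound 3 are a step that the two limits leave unreadable from compound 1 to compound 3 and a step that the two limits leave unreadable from compound 2 to compound 3. Neither is this change and neither has a readable size, so no step beyond the scatter is expected in this assay. The expected step is a number no higher from compound 3 to compound 4 (the limit leaves the size open). For compound 4 the estimated value is 100000 nM, with an expected range from 40000 nM to 200000 nM.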

Compound 4, half-maximal inhibitory concentration: 93000 nM
Compound 4: middle estimate off by 1.1-fold (0.03 log units), on the high side, and the stated range covers the measured number.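

With chloro in place of hydrogen, on an aromatic carbon para to a large group, this assay shows an at least 1.0-fold lower number from compound 3 to compound 4 (0.03 log units; that floor lies within the scatter). Within the data shown here, compound 4 is thus the first compound here with a number of its own, though the change cannot be sized, since the floor lies within the scatter and compound 3 has only a limit. The other compounds offer no number for comparison: the limit of > 100000 nM in this assay, at which 3 of the 4 values shown sit.

The compounds shown leave open whether an amine or a carboxylic acid at this place would shift the number. They also leave open whether chloro would give a number with the groups of compound 1 or compound 2.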